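The compounds below may be only part of what the source reports. "The series", "measured", "known", "first", "only" and "open" are said of these compounds alone.

Measured compounds:
- compound 1, `CC[C@H]1c2c(cc(F)c(F)c2O)[C@H](Nc2cccc3[nH]c(=O)ccc23)[C@@](O)(C(F)(F)F)C1OC`: 6.31 nM
- compound 2, `CCSC[C@@](O)([C@@H](Nc1cccc2nc(C)ccc12)c1ccc(F)cc1OC)C(F)(F)F`: 5.01 nM

In a functional assay on THP-1 cells (Homo sapiens) (a lower number here means a stronger inhibitor, a higher number a weaker inhibitor), compound 1 gives 6.31 nM, and in this assay compound 2 gives 5.01 nM. Of the two numbers, that of compound 2 is the lower one, but its gap to compound 1 lies within the scatter of repeated measurements, so the two compounds cannot be told apart on these numbers. For the measured compounds named here, the two also differ in several places at once, so no single structural step between them can be read off.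

Compound 3, `CCSC[C@@](O)([C@@H](Nc1cccc2nc(C)ccc12)c1ccc(Cl)c(F)c1OC)C(F)(F)F`, has not yet been measured in this assay. It differs from compound 2 in one place: 4-chloro-3-fluoro-2-methoxyphenyl in place of 4-fluoro-2-methoxyphenyl on a saturated chain carbon bound to a nitrogen on an aromatic ring and a saturated chain carbon. Going by the values given here, no step between measured compounds involving this kind of change is available, so the expectation rests on the closeness of compound 1 and compound 2 alone. With a single halogen added on an aromatic ring that already carries one, a step of no more than the scatter, in either direction, is expected from compound 2 to compound 3, that is a 1.0-fold lower number from compound 2 to compound 3 (0.00 log units; within the scatter). Compound 3 is therefore estimated at 5 nM, within a range from 2 nM to 13 nM.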

Compound 3, half-maximal inhibitory concentration: 1.59 nM
The estimate for compound 3 lay 3.1-fold (0.50 log units) above the measured number; the whole stated range lies above it.
By their numbers in this assay, from the lowest: compound 3; then compounds 2 and 1 (each within the scatter of the next).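

In this assay, the group on this saturated chain carbon proves sensitive to substitution: 4-chloro-3-fluoro-2-methoxyphenyl in place of 4-fluoro-2-methoxyphenyl gives a 3.2-fold lower number from compound 2 to compound 3 (0.50 log units; beyond the scatter), whereas the earlier pair differed in several places at once and could say nothing about any single position. The change is small on paper, adding one heavy atom to the group and leaving its counts of hydrogen-bond donors and acceptors as they were, so a modest edit to this ring is enough to move the number past the usual scatter. No accompanying measurement indicates why the number falls.

As far as these compounds go, two things change together in this step, so it remains open whether the chlorine or the added fluorine accounts for it; a 4-chloro-2-methoxyphenyl group on the same carbon would help separate the two. Also open, from the compounds shown here alone, is what a bromine or a nitrile in place of the chlorine would do, and whether the number would keep falling or turn back up.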